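Fluorine pattern on the benzyl group and cytotoxicity

The source may report more compounds than this note shows. Statements on the series, on what has been measured and on what is new or still open speak of the compounds shown alone.

Of the compounds shown here, two sharing one core have been tested in an ADME assay on C8166 cells (Homo sapiens) for cytotoxicity, read by MTT assay; on this read-out lower numbers stand for higher toxicity in this test and higher numbers for lower toxicity in this test. Compound 1 `Cc1ccc(Cn2cc(C(=O)O)c(=O)c3c(O)c(Cc4cccc(Cl)c4F)ccc32)cc1` gives 256000 nM in this assay. Among the compounds with values here, compound 2 `O=C(O)c1cn(Cc2ccccc2F)c2ccc(Cc3cccc(Cl)c3F)c(O)c2c1=O` gives 44900 nM in this assay, the lower of the two numbers; the step of a 5.7-fold lower number from compound 1 to compound 2 (0.76 log units; beyond the scatter) is the only measured change at this position. Compound 3 `O=C(O)c1cn(Cc2ccc(F)c(F)c2)c2ccc(Cc3cccc(Cl)c3F)c(O)c2c1=O` has not yet been measured. It differs from compound 2 by 3,4-difluorophenyl in place of 2-fluorophenyl on a saturated chain carbon bound to an aromatic nitrogen. Within the data shown here, the one measured step, a 5.7-fold lower number from compound 1 to compound 2 (0.76 log units; beyond the scatter), involves the same place but a different pair of groups, so it bears only loosely on the present change; the data give no example of adding a second fluorine. For compound 3 a step of a 1.1-fold lower number from compound 2 to compound 3 (0.05 log units; within the scatter) is expected, that is, no change beyond the scatter. Compound 3 is therefore estimated at 40000 nM in this assay, within a range from 15000 nM to 120000 nM.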

Compound 3, half-maximal cytotoxic concentration: 71400 nM
Beside the measured number, compound 3's estimate is 1.8-fold (0.25 log units) below it; low and high end bracket the measured number.
By their numbers in this assay, from the lowest: compounds 2 and 3 (each within the scatter of the next); then compound 1.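

In this assay, replacing 2-fluorophenyl with 3,4-difluorophenyl on this saturated chain carbon gives a 1.6-fold higher number from compound 2 to compound 3 (0.20 log units; within the scatter), so compound 2 and compound 3 cannot be told apart here despite the different fluorine patterns. The second fluorinated group also departs from the 4-methylphenyl of compound 1, with a 3.6-fold lower number from compound 1 to compound 3 (0.55 log units; beyond the scatter) alongside a 5.7-fold lower number from compound 1 to compound 2 (0.76 log units; beyond the scatter), so among these compounds both fluorophenyl groups stand apart from the methyl-bearing one, and no compound shown goes against this. Nothing available explains this pattern.

The compounds shown leave open how a plain phenyl or a pyridyl ring would read at this position. They therefore do not settle whether the separation from compound 1 goes with the fluorine atoms or with the absence of the methyl group.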